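Aryl substituent changes on the shared core

The source may hold more compounds than are shown below. What is called first, only, known or untested is meant among the compounds shown, and "the series" means these compounds.

Compound 1, `COC(=O)C1=C(C)N=C(C)/C(=C(\O)OC)C1c1cccc(OC)c1`: 191 nM
Compound 2, `COC(=O)C1=C(C)N=C(C)/C(=C(\O)OC)C1c1ccccc1Cl`: 2.19 nM
Compound 3, `COC(=O)C1=C(C)N=C(C)/C(=C(\O)OC)C1c1cccc(C#N)c1`: 34.7 nM

All three numbers come from a functional assay (muscle tissue) with Cavia porcellus as the target; on this read-out higher numbers stand for an effect only at larger amounts of compound and lower numbers for an effect already at smaller amounts. Compound 3 stands second highest of the three: the step of a 5.5-fold lower number from compound 1 to compound 3 (0.74 log units; beyond the scatter) is modest, while the step of a 16-fold higher number from compound 2 to compound 3 (1.20 log units; beyond the scatter) is large, so compound 3 sits well apart from both neighbours.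

Among the measured compounds shown here, compound 4, `COC(=O)C1=C(C)N=C(C)/C(=C(\O)OC)C1c1cccc(F)c1`, has not yet been read in this assay. It differs from compound 3 by fluoro in place of cyano on an aromatic carbon.

For the measured compounds named here, only one measured step touches this aromatic carbon, a 5.5-fold lower number from compound 1 to compound 3 (0.74 log units; beyond the scatter), and it exchanged methoxy for cyano rather than cyano for fluoro. Fluoro itself has no measured precedent in the set, so the direction is not fixed by the data. Because a 5.5-fold lower number from compound 1 to compound 3 (0.74 log units; beyond the scatter) shows that a group swap on this aromatic carbon moves the number only modestly, a step of at most modest size is expected, most likely towards a somewhat higher number. Compound 4 is therefore estimated at 55 nM in this assay, with a range from 14 nM to 220 nM. That estimate means a step of a 1.6-fold higher number from compound 3 to compound 4 (0.20 log units; within the scatter), expected to lie near the edge of the scatter.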

Compound 4, half-maximal effective concentration: 20.9 nM
Estimate against measurement, compound 4: 2.6-fold (0.42 log units) above; the range from low to high includes it.
By their numbers in this assay, from the lowest: compound 2; then compounds 4 and 3 (each within the scatter of the next); then compound 1.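

In this assay fluoro and cyano on this aromatic carbon cannot be told apart: the step of a 1.7-fold lower number from compound 3 to compound 4 (0.22 log units; within the scatter) shows that a nitrile can give way to a single fluorine atom with no readable difference. Methoxy is the group that stands apart here so far, with a 9.1-fold lower number from compound 1 to compound 4 (0.96 log units; beyond the scatter) running the same way as a 5.5-fold lower number from compound 1 to compound 3 (0.74 log units; beyond the scatter) for the nitrile. The 3-fluorophenyl group still does not match the 2-chlorophenyl group, and the step of a 9.5-fold higher number from compound 2 to compound 4 (0.98 log units; beyond the scatter) remains beyond the scatter.

No supporting evidence stands beside these numbers to explain them. As far as these compounds go, how an amine or a carboxylic acid on this aromatic carbon would read remains open, as does whether the two groups that cannot be told apart would also match each other on other aryl positions.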